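From a Cyclic Amine to an Open-Chain Amine

This account rests on a few compounds, and the source may have more. Where it says the series, first, only, none or still open, it means among the compounds named here.

Compound 1 `Cc1nnc(CN2CCCC2)n1-c1ccc(Cl)cc1C(=O)c1ccccc1`: 0.4 mg/kg
Compound 2 `Cc1nnc(CN2CCCC2)n1-c1ccc(Cl)cc1C(=O)c1ccccc1Cl`: 1.3 mg/kg

In a functional assay on the whole organism (strain CF-1) for inhibition, with Mus musculus as the target (on this read-out lower numbers stand for an effect already at smaller amounts and higher numbers for an effect only at larger amounts of compound), compound 1 gives 0.4 mg/kg, the lowest of the two numbers recorded. Its nearest neighbour is compound 2, which gives 1.3 mg/kg; the step of a 3.3-fold higher number from compound 1 to compound 2 (0.51 log units; beyond the scatter) goes with chloro in place of hydrogen on an aromatic carbon, a change that leaves the amine side of the molecule untouched.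

Compound 3 `CCNCc1nnc(C)n1-c1ccc(Cl)cc1C(=O)c1ccccc1` differs from compound 1 in another place altogether: ethylamino in place of pyrrolidin-1-yl on a saturated chain carbon bound to an aromatic carbon. For the measured compounds named here, no measured step concerns that part of the molecule, so the chloro step between compound 1 and compound 2 offers no direct guide. With the shared core kept intact, the expectation is a small step at most, a 1.8-fold higher number from compound 1 to compound 3 (0.24 log units; within the scatter), leaning towards a somewhat higher number but possibly none beyond the scatter. Compound 3 is therefore expected to give about 0.7 mg/kg, in the range from 0.25 mg/kg to 2 mg/kg.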

Compound 3, dose for half-maximal effect: 0.2 mg/kg
Compound 3: the middle estimate sits 3.5-fold (0.54 log units) above what was measured; the whole stated range lies above it.
By their numbers in this assay, from the lowest: compounds 3 and 1 (each within the scatter of the next); then compound 2.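

Replacing the ring with an open chain, ethylamino in place of pyrrolidin-1-yl on a saturated chain carbon bound to an aromatic carbon, gives a 2.0-fold lower number from compound 1 to compound 3 (0.30 log units; within the scatter) in this assay. The five-membered ring is therefore not required for activity at this level, and the swap to a smaller group carrying a hydrogen-bond donor leaves compound 1 and compound 3 indistinguishable on this read-out. No measurement available here explains this tolerance.

The compounds shown leave open whether a primary amine, dimethylamino or a longer chain such as butylamino would fare equally well at this place. They also leave open whether chloro in place of hydrogen on an aromatic carbon would, on the ethylamino compound, repeat the step seen as a 3.3-fold higher number from compound 1 to compound 2 (0.51 log units; beyond the scatter).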